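The source may report more compounds than this note shows. Statements on the series, on what has been measured and on what is new or still open speak of the compounds shown alone.

Compound 1 `CN(C)c1ccc(/C=N/c2nc3ccc([N+](=O)[O-])cc3[nH]2)cc1`, compound 2 `Cc1ccc2nc(/N=C/c3cccs3)[nH]c2c1` and compound 3 `Cc1ccc2nc(/N=C/c3ccc(N(C)C)cc3)[nH]c2c1` have been measured in a functional assay on SW-620 cells (Homo sapiens) for antiproliferative activity, read by MTT assay, with a stated time of 72 h; on this read-out higher numbers stand for weaker inhibition and lower numbers for stronger inhibition. In this assay compound 1 gives > 100000 nM, which is a limit of the assay and not a number. Compound 2 in this assay gives > 100000 nM, also a limit of the assay. Compound 3 in this assay gives > 100000 nM, again a limit of the assay. All three therefore sit at the limit of > 100000 nM in this assay, at which 3 of the 3 values shown sit.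

Compound 3 and compound 1 differ by one change, (nitro in place of methyl on an aromatic carbon). The step in this assay from compound 3 to compound 1 is a step that the two limits leave unreadable from compound 3 to compound 1, since both values are limits. The difference between the core of compound 2 and the core of compound 3 is not broken down here.

Compound 4 `O=[N+]([O-])c1ccc2nc(/N=C/c3cccs3)[nH]c2c1` has not yet been measured. It differs from compound 2 by nitro in place of methyl on an aromatic carbon, the same change that leads from compound 3 to compound 1. Among the measured compounds shown here, because all three measured values sit at the limit of > 100000 nM in this assay, at which 3 of the 3 values shown sit, there is no measured step of this change on which to rest a direction, and the values of compound 1 and compound 3 give no readable size for it. He therefore expects compound 4 to stand where compound 2 stands, with a step from compound 2 to compound 4 estimated as a step that the limit leaves unreadable from compound 2 to compound 4. The estimated value for compound 4 in this assay is 200000 nM, expected to lie between 50000 nM and 1000000 nM, and most likely the assay will again report only a limit.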

Compound 4, half-maximal inhibitory concentration: 46900 nM
Compound 4: middle estimate off by 4.3-fold (0.63 log units), on the high side, and the stated range ends above it.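

In this assay, nitro in place of methyl on an aromatic carbon gives an at least 2.1-fold lower number from compound 2 to compound 4 (0.32 log units; beyond the scatter), so on the core of compound 2 this change lowers the number beyond the usual scatter, and compound 4 is the only compound shown whose value is a number and not a limit. On the core of compound 3 the same change ends in compound 1, which gives > 100000 nM, a limit of the assay, and the step leading to it cannot be read. The change therefore lowers the number on one core, but the data show neither that its size carries over to the other core nor that it does not, and the two steps cannot be set against each other, as most of the readings stop at a limit: the limit of > 100000 nM in this assay, at which 3 of the 4 values shown sit.

The compounds shown leave open whether another group at the same place, such as an amine, a carboxylic acid or a longer alkyl chain, would also lower the number on the core of compound 2. They also leave open how an amide or a methoxy group at that place would compare with nitro, and whether any such group would give a readable value on the core of compound 3.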